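The compounds below may be only part of what the source reports. "The series", "measured", "known", "first", "only" and "open" are said of these compounds alone.

Compound 1 `COc1ncnc2c1c(-c1ccsc1)cn2[C@@H]1O[C@H](CO)[C@@H](O)[C@H]1O` is the starting point. Among the measured compounds shown here, in an ADME assay on BJ cells (Homo sapiens), read by MTT assay, with a stated time of 72 h (on this read-out lower numbers stand for stronger inhibition and higher numbers for weaker inhibition), compound 1 gives 64300 nM, which is the only full number among the values shown here. Compound 2 `COc1nc(N)nc2c1c(-c1ccsc1)cn2[C@@H]1O[C@H](CO)[C@@H](O)[C@H]1O` is the same core with an amino group added. In this assay compound 2 gives > 100000 nM, and this is a limit of the assay rather than a number. For the measured compounds named here, the step of an at least 1.5-fold higher number from compound 1 to compound 2 (0.19 log units; that floor lies within the scatter), amino in place of hydrogen on an aromatic carbon, is the only measured step available, and it runs into (the limit of > 100000 nM in this assay, at which 1 of the 2 values shown sits), so its true size is not known. Compound 3 `CNc1ncnc2c1c(-c1ccsc1)cn2[C@@H]1O[C@H](CO)[C@@H](O)[C@H]1O` differs from compound 1 by methylamino in place of methoxy on an aromatic carbon. Going by the values given here, no measured step covers that exact change, and the single step that does exist moved the number upward or not at all. In this assay a small step, if anything toward weaker inhibition, is therefore expected, a 1.2-fold higher number from compound 1 to compound 3 (0.09 log units; within the scatter). Compound 3 is estimated at 80000 nM, within a range from 30000 nM to 200000 nM.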

Compound 3, half-maximal inhibitory concentration: > 100000 nM
Compound 3: no number, only a limit; the forecaster's own chance of this, stated with the estimate: 35%; middle value at least 1.2-fold (0.09 log units) away from the limit.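

Replacing methoxy with methylamino on this aromatic carbon gives an at least 1.5-fold higher number from compound 1 to compound 3 (0.19 log units; that floor lies within the scatter) in this assay. This is the first change shown at the methoxy position itself, and the swap, which brings in a hydrogen-bond donor, gives no sign of stronger inhibition. The value for compound 3 is a limit and not a number, so the true size of this step is unknown because it runs into the ceiling of the read-out: the limit of > 100000 nM in this assay, at which 2 of the 3 values shown sit.

As far as these compounds go, how far compound 3 really lies from compound 1 therefore stays open. Also open, from the compounds shown here alone, is whether a different group on this same carbon, such as ethoxy, dimethylamino or a longer alkyl chain, would give a full number in this assay and so allow a real comparison with compound 1.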